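The source may hold more compounds than are shown below. What is called first, only, known or untested is meant among the compounds shown, and "the series" means these compounds.

Measured so far:
Compound 1 `N=C1NC(=O)/C(=C\c2c[nH]c3c(Br)cccc23)N1` gives 1410 nM in an in vitro assay on HEK293 cells for displacement of a labelled ligand from 5-hydroxytryptamine receptor 6 (Homo sapiens); on this read-out lower numbers stand for stronger inhibition and higher numbers for weaker inhibition.
Compound 2 `C/N=C1\N(C)C(=O)/C(=C\c2c[nH]c3ccccc23)N1C` gives 1720 nM in this assay.

Of the two numbers, compound 2 shows the higher one, but the gap to compound 1 lies within the usual scatter, so the two cannot be told apart. Compound 3 `C/N=C1\N(C)C(=O)/C(=C\c2c[nH]c3c(Br)cccc23)N1C` is not yet measured. It differs from compound 2 by bromo in place of hydrogen on an aromatic carbon. Within the data shown here, no measured pair shows this change on its own, so the step is expected to stay within the scatter, without a clear direction, as a 1.2-fold lower number from compound 2 to compound 3 (0.09 log units; within the scatter). Compound 3 is therefore expected to give about 1400 nM, between 500 nM and 4000 nM.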

Compound 3, inhibition constant: 7300 nM
Estimate against measurement, compound 3: 5.2-fold (0.72 log units) below, outside the stated range (above it).
By their numbers in this assay, from the lowest: compounds 1 and 2 (each within the scatter of the next); then compound 3.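

Bromo in place of hydrogen on this aromatic carbon, ortho to a fused ring, can now be read on its own for the first time. In this assay the change gives a 4.2-fold higher number from compound 2 to compound 3 (0.63 log units; beyond the scatter), so on this core the position does not accept the swap without a loss in binding. Nothing measured here explains why the number rises.

The compounds shown leave open whether chloro, methoxy or an amine on this same carbon would behave as bromo does. They also leave open whether hydrogen and bromo differ this way on the core of compound 1.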